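Hydroxamate chain lengthening on two cores: working notes

A few compounds are considered here, and "the series" means these few. Any claim that something is new, unique, unknown or untested is made for them only; others in the source may bear on it.

The set holds two cores, each carrying a saturated chain on an aromatic nitrogen that ends in a hydroxamic acid. Compound 2 `Nc1ncnc2c1c(-c1cnc3[nH]ccc3c1)nn2CCCCCCC(=O)NO` and compound 1 `Nc1ncnc2c1c(-c1cnc3[nH]ccc3c1)nn2CCCCCCCCCC(=O)NO` share the first core; compound 3 `Nc1nc2cc(-c3nn(CCCCCC(=O)NO)c4ncnc(N)c34)ccc2o1` and the not yet measured compound 4 `Nc1nc2cc(-c3nn(CCCCCCCCC(=O)NO)c4ncnc(N)c34)ccc2o1` share the second. The difference between the two cores is not broken down here.

In a functional assay on HCT-116 cells (Homo sapiens) for inhibition, read by MTT assay, with a stated time of 72 h (a higher number here means a weaker inhibitor, a lower number a stronger inhibitor), compound 2 gives 9860 nM. The longer chain, (3-(hydroxycarbamoyl)propyl in place of hydroxycarbamoyl on a saturated chain carbon, six bonds along the chain from an aromatic nitrogen), leads to compound 1, which in this assay gives 18700 nM; the step is a 1.9-fold higher number from compound 2 to compound 1 (0.28 log units; within the scatter). On the second core compound 3 gives 21500 nM in this assay, a number close to that of compound 1 and separated from compound 2 by a gap beyond the scatter.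

Compound 4 carries the same kind of change on the second core: 3-(hydroxycarbamoyl)propyl in place of hydroxycarbamoyl on a saturated chain carbon, five bonds along the chain from an aromatic nitrogen. The places are not identical: in the first pair the chain carbon lies six bonds along the chain from an aromatic nitrogen, in the second five bonds along the chain from an aromatic nitrogen, so the change is of the same kind rather than the same. Within the data shown here, only one measured pair informs the expectation. For compound 4 the expected step is a 1.4-fold higher number from compound 3 to compound 4 (0.14 log units; within the scatter), because the same kind of change on the first core gave a 1.9-fold higher number from compound 2 to compound 1 (0.28 log units; within the scatter). In this assay compound 4 is therefore estimated at 30000 nM, with a likely range from 13000 nM to 70000 nM.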

Compound 4, half-maximal inhibitory concentration: 2980 nM
Compound 4: middle estimate off by 10-fold (1.00 log units), on the high side; measured number below the stated range.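

The same change does not carry over from one core to the other in this assay: the same change on two cores in this assay, a 1.9-fold higher number (0.28 log units; within the scatter) from compound 2 to compound 1 and a 7.2-fold lower number (0.86 log units; beyond the scatter) from compound 3 to compound 4, 14-fold (1.14 log units) apart, beyond the scatter of two such steps

On the second core, lengthening the chain gives a 7.2-fold lower number from compound 3 to compound 4 (0.86 log units; beyond the scatter), whereas on the first core the step, a 1.9-fold higher number from compound 2 to compound 1 (0.28 log units; within the scatter), shows no change that can be told from scatter. This rests on one pair per core, and the place of the change also differs, six bonds along the chain from an aromatic nitrogen on the first core and five on the second, so the notes show neither whether the core or the starting chain length decides the outcome nor any general rule for the series.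

Among these compounds, still open is how each core behaves across a fuller run of chain lengths, including a chain longer than that of compound 4 and, on each core, the chain length so far seen only on the other. Also open, on these data alone, is whether the 2980 nM of compound 4 depends on the hydroxamic acid end, which a carboxylic acid or a primary amide at the same chain end would test.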